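Methyl Added to the Piperidin-1-yl of Compound 2

The compounds below may be only part of what the source reports. "The series", "measured", "known", "first", "only" and "open" are said of these compounds alone.

Of the compounds shown here, three built on one shared core have been measured in a functional assay on HT-29 cells (Homo sapiens) for cytotoxicity, read by MTT assay, with a stated time of 72 h; a lower number here means a stronger inhibitor, a higher number a weaker inhibitor. Compound 1 `COc1cc2c(Oc3ccc(NC(=O)c4nn(-c5ccccc5)c(=O)c5ccccc45)cc3F)ccnc2cc1OCCCN1CCCCC1` gives 1310 nM. Compound 2 `COc1cc2c(Oc3ccc(NC(=O)c4nn(-c5ccc(Br)cc5)c(=O)c5ccccc45)cc3F)ccnc2cc1OCCCN1CCCCC1` gives 770 nM. Compound 3 `COc1ccc(-n2nc(C(=O)Nc3ccc(Oc4ccnc5cc(OCCCN6CCCCC6)c(OC)cc45)c(F)c3)c3ccccc3c2=O)cc1` gives 1450 nM. Of these three numbers, that of compound 2 is the lowest, but the step of a 1.7-fold lower number from compound 1 to compound 2 (0.23 log units; within the scatter) and the step of a 1.9-fold higher number from compound 2 to compound 3 (0.27 log units; within the scatter) both lie within the scatter, as does a 1.1-fold higher number from compound 1 to compound 3 (0.04 log units; within the scatter), so no ordering of the three can be read from them.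

Compound 4 `COc1cc2c(Oc3ccc(NC(=O)c4nn(-c5ccc(Br)cc5)c(=O)c5ccccc45)cc3F)ccnc2cc1OCCCN1CCC(C)CC1` has not yet been measured. It differs from compound 2 by methyl in place of hydrogen on a saturated ring carbon, that is, piperidin-1-yl becomes 4-methylpiperidin-1-yl at the end of the chain. None of the three measured steps touches this saturated ring; all of them concern the substituent on the aromatic ring attached to the ring nitrogen of the core, and all three stayed within the scatter. Going by the values given here, there is therefore no measured step that bears directly on the change, and nothing among the measured compounds that would point to a step beyond the scatter in either direction.

The expectation for compound 4 in this assay is accordingly a number close to that of compound 2, a step of no change at the digits printed from compound 2 to compound 4 (within the scatter), giving an estimate of 770 nM with a range from 350 nM to 1700 nM.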

Compound 4, half-maximal inhibitory concentration: 920 nM
Compound 4: the middle estimate sits 1.2-fold (0.08 log units) below what was measured, within the range that was stated.
By their numbers in this assay, from the lowest: compounds 2, 4, 1 and 3 (each within the scatter of the next).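

In this assay, the methyl on the saturated ring at the end of the chain produces a 1.2-fold higher number from compound 2 to compound 4 (0.08 log units; within the scatter). Going by these compounds alone, this is the first measured change at that ring, since every earlier step concerned the substituent on the aromatic ring attached to the ring nitrogen of the core, and it shows that placing methyl on a carbon three ring bonds from the ring nitrogen, turning piperidin-1-yl into 4-methylpiperidin-1-yl, does not move the number beyond the scatter in this bromo-substituted pair. No information is available that bears on the reason for this result.

The compounds shown leave open whether a larger change at the end of the chain, such as morpholin-4-yl, 4-hydroxypiperidin-1-yl or dimethylamino in place of piperidin-1-yl, or a longer chain leading to the ring, would also stay within the scatter. They also leave open whether the same methyl would give a similar step in a compound carrying hydrogen or methoxy in place of the bromo group.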